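From 1,3-thiazol-4-yl to 1H-imidazol-2-yl

A few compounds are considered here, and "the series" means these few. Any claim that something is new, unique, unknown or untested is made for them only; others in the source may bear on it.

- compound 1 `Cc1nc(-c2nc([C@@H](O)[C@H](O)[C@H](O)CO)c[nH]2)cs1`: 19.4 mL/min/kg
- compound 2 `OC[C@@H](O)[C@@H](O)[C@H](O)c1c[nH]c(-c2cscn2)n1`: 12.7 mL/min/kg

Within the data shown here, in an in vivo ADME assay on the whole organism (strain 129/SvEvBrd x C57BL/6) for pharmacokinetics, with Mus musculus as the target, at a dose of 1 mg/kg by the intravenous route (a lower number here means slower removal, a higher number faster removal of the compound), compound 2 stands close to compound 1, the only other compound measured, with a 1.5-fold lower number from compound 1 to compound 2 (0.18 log units; within the scatter). Compound 3 `OC[C@@H](O)[C@@H](O)[C@H](O)c1c[nH]c(-c2ncc[nH]2)n1` differs from compound 2 by one exchange: 1H-imidazol-2-yl in place of 1,3-thiazol-4-yl on an aromatic carbon. Among the measured compounds shown here, the single measured step is a different change, hydrogen in place of methyl on an aromatic carbon, and no measured step exchanges the 1,3-thiazol-4-yl group itself. The data therefore give no direction, and the expectation rests on compound 2 at 12.7 mL/min/kg. The expected outcome is a 1.1-fold higher number from compound 2 to compound 3 (0.04 log units; within the scatter), with nothing expected beyond the scatter. Compound 3 is estimated at 14 mL/min/kg, within an expected range of 6 mL/min/kg to 32 mL/min/kg.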

Compound 3, clearance: 31.5 mL/min/kg
Estimate against measurement, compound 3: 2.3-fold (0.35 log units) below, within the range that was stated.
By their numbers in this assay, from the lowest: compounds 2, 1 and 3 (each within the scatter of the next, the first and the last beyond it).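

In this assay, among these compounds, this position on the shared core responds to the ring it carries: 1H-imidazol-2-yl in place of 1,3-thiazol-4-yl gives a 2.5-fold higher number from compound 2 to compound 3 (0.39 log units; beyond the scatter) and is the only modest step beyond the scatter so far. Measured against 2-methyl-1,3-thiazol-4-yl, the same entering ring gives a 1.6-fold higher number from compound 1 to compound 3 (0.21 log units; within the scatter) and stays within it. Nothing available explains the step.

Still open, as far as these compounds go, is whether a methyl group on the 1H-imidazol-2-yl ring would change the number. The compounds shown also leave open how an amine or a carboxylic acid at this position would compare.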